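Swapping hydroxy for chloro on compound 3

A few compounds are considered here, and "the series" means these few. Any claim that something is new, unique, unknown or untested is made for them only; others in the source may bear on it.

Compound 1 `CCCCCCCCCCCCOc1cccc(O)c1C(=O)/C=C/c1ccc(O)cc1`: > 30000 nM
Compound 2 `O=C(/C=C/c1ccc(O)cc1)c1c(O)cccc1OCC1CCCCC1`: > 30000 nM
Compound 3 `CCCCCCCCCCOc1cccc(O)c1C(=O)/C=C/c1ccc(O)c(Cl)c1`: > 30000 nM

These three results come from an ADME assay on RAW264.7 cells (Mus musculus) for cytotoxicity, read by MTT assay (a lower number here means a stronger inhibitor, a higher number a weaker inhibitor), and each one is a limit of the assay, not a number. Together they stand at the limit of > 30000 nM in this assay, at which 3 of the 3 values shown sit. Compound 3 is therefore not ranked against the other two, and its result of > 30000 nM is simply a limit.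

Compound 4 `CCCCCCCCCCOc1cccc(O)c1C(=O)/C=C/c1ccc(Cl)c(Cl)c1` differs from compound 3 in one place, so that 3-chloro-4-hydroxyphenyl becomes 3,4-dichlorophenyl: chloro in place of hydroxy on an aromatic carbon. Among the measured compounds shown here, no measured pair shows what this change does in this assay. For the measured compounds named here, the only guide is compound 3 with its > 30000 nM, so no step beyond the scatter is expected, in either direction. The expected step is a number no higher from compound 3 to compound 4 (the limit leaves the size open). A report of only a limit is also the likeliest outcome. For compound 4 the estimate is 30000 nM, with an expected range of 12000 nM to 60000 nM.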

Compound 4, half-maximal inhibitory concentration: > 30000 nM
Compound 4: no number, only a limit (the forecaster's own chance of this, stated with the estimate: 70%); the middle value sits exactly at the limit.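

Among the compounds shown here, compound 3 and compound 4 each give only a limit in this assay and not a number, so no step between them can be read: the limit of > 30000 nM in this assay, at which 4 of the 4 values shown sit.

The compounds shown leave open whether chloro in place of hydroxy on an aromatic carbon changes this result at all.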